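Shortening the side-chain amide: compound 3 to compound 4

This account rests on a few compounds, and the source may have more. Where it says the series, first, only, none or still open, it means among the compounds named here.

Measured to date in a functional assay on the whole organism (Tail, strain ICR) with Mus musculus as the target, in the tail flick test, with a stated time of 30 min, at a dose of 25 umol/kg by the oral route; on this read-out lower numbers stand for a weaker effect and higher numbers for a stronger effect at the one dose given:
compound 1 `O=C(CN(c1nc(Cl)nc2[nH]cnc12)C1CC1)N[C@@H](CC(=O)OCc1ccccc1)C(=O)OCc1ccccc1`: 34.7%
compound 2 `NCCCC[C@H](NC(=O)CN(c1nc(Cl)nc2[nH]cnc12)C1CC1)C(=O)OCc1ccccc1`: 26.1%
compound 3 `NC(=O)CC[C@H](NC(=O)CN(c1nc(Cl)nc2[nH]cnc12)C1CC1)C(=O)OCc1ccccc1`: 30.8%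

All three share the same core and differ only in the group on the saturated chain carbon two bonds along the chain from an amide-type nitrogen and a carbonyl carbon. Compound 3 stands second highest of the three numbers; its nearest neighbour is compound 1, a number 3.9 percentage points lower from compound 1 to compound 3 (within the scatter), and its furthest is compound 2, a number 4.7 percentage points higher from compound 2 to compound 3 (within the scatter). Every gap among the three is within the scatter, so the three read as one level in this assay.

Compound 4 `NC(=O)C[C@H](NC(=O)CN(c1nc(Cl)nc2[nH]cnc12)C1CC1)C(=O)OCc1ccccc1` is not yet measured. The change from compound 3 is carbamoyl in place of carbamoylmethyl on a saturated chain carbon, two bonds along the chain from an amide-type nitrogen and a carbonyl carbon. For the measured compounds named here, the steps that bear on it are the exchange that gave compound 3 from compound 1, a number 3.9 percentage points lower from compound 1 to compound 3 (within the scatter), and the one that gave compound 3 from compound 2, a number 4.7 percentage points higher from compound 2 to compound 3 (within the scatter), both within the scatter. A change of the same kind, read one bond further out, therefore carries no expectation of a step beyond the scatter in this assay, and compound 4 is expected at a number 0.8 percentage points lower from compound 3 to compound 4 (within the scatter). The estimate for compound 4 is 30%, with a range from 19% to 41%.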

Compound 4, a percentage reported as activity, at one dose (the size of the read-out at that dose, not a potency): 24.4%
Estimate against measurement, compound 4: 5.6 percentage points above, within the range that was stated.
By their numbers in this assay, from the lowest: compounds 4, 2, 3 and 1 (each within the scatter of the next, the first and the last beyond it).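

In this assay, carbamoyl in place of carbamoylmethyl gives a number 6.4 percentage points lower from compound 3 to compound 4 (within the scatter) and carbamoyl in place of 3-aminopropyl gives a number 1.7 percentage points lower from compound 2 to compound 4 (within the scatter) at this saturated chain carbon, so the amide side chain cut one bond further out does not separate compound 4 from either compound. The series now has its first step beyond the scatter, a number 10.3 percentage points lower from compound 1 to compound 4 (beyond the scatter) with amino in place of benzyloxy on a carbonyl carbon, although the step is modest. For the compounds shown here, the same comparison with the amide one bond further out, a number 3.9 percentage points lower from compound 1 to compound 3 (within the scatter) stays inside the scatter, so at this one dose only the pair of compound 1 and compound 4 can be told apart.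

A carboxylic acid in place of the carbamoyl of compound 4, or a longer chain ending in an amine or a benzyl ester, would test whether the gap depends on the benzyloxy group itself or on chain length. Going by these compounds, whether any of these readings would hold at other doses or at times other than the one stated remains open.

Nothing at hand gives a cause for any of these steps.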